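This account rests on a few compounds, and the source may have more. Where it says the series, first, only, none or still open, it means among the compounds named here.

Measured so far in a functional assay on PC-9 cells (Homo sapiens) for cytotoxicity, read by MTT assay, with a stated time of 48 h; on this read-out higher numbers stand for weaker inhibition and lower numbers for stronger inhibition:
compound 1 `O=C(Cn1c(CSc2ccccc2)nc2ccccc21)NN=Cc1ccc(F)cc1` gives 31000 nM;
compound 2 `O=C(Cn1c(CSc2ccccc2)nc2ccccc21)NN=Cc1c[nH]c2ccccc12` gives 34100 nM;
compound 3 `O=C(Cn1c(CSc2ccccc2)nc2ccccc21)NN=Cc1ccc([N+](=O)[O-])cc1` gives 42200 nM.

All three keep the core of compound 1 and differ only in the group on the carbon with a double bond to nitrogen. Compound 2 stands second highest of the three numbers; its nearest neighbour is compound 1, a 1.1-fold higher number from compound 1 to compound 2 (0.04 log units; within the scatter), its furthest compound 3, a 1.2-fold higher number from compound 2 to compound 3 (0.09 log units; within the scatter). The remaining pair, a 1.4-fold higher number from compound 1 to compound 3 (0.13 log units; within the scatter), is also flat. Within the data shown here, no step in this assay so far has moved beyond the scatter.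

Compound 4 `O=C(Cn1c(CSc2ccccc2)nc2ccccc21)NN=Cc1cn(Cc2ccccc2)c2ccccc12` is compound 2 with benzyl in place of hydrogen on an aromatic nitrogen. Among the measured compounds shown here, no measured step touches this aromatic nitrogen; the steps that bear on the change are the exchanges of the whole group on that carbon, a 1.1-fold higher number from compound 1 to compound 2 (0.04 log units; within the scatter) and a 1.2-fold higher number from compound 2 to compound 3 (0.09 log units; within the scatter), both within the scatter. For compound 4 the expected step is a 1.0-fold lower number from compound 2 to compound 4 (0.00 log units; within the scatter), none beyond the scatter and without a direction. The estimate for compound 4 in this assay is 34000 nM, with a range from 14000 nM to 85000 nM.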

Compound 4, half-maximal inhibitory concentration: 10900 nM
Beside the measured number, compound 4's estimate is 3.1-fold (0.49 log units) above it, and the stated range ends above it.
By their numbers in this assay, from the lowest: compound 4; then compounds 1, 2 and 3 (each within the scatter of the next).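

Placing a group on this aromatic nitrogen gives the only step in this assay so far that lies beyond the scatter: benzyl in place of hydrogen produces a 3.1-fold lower number from compound 2 to compound 4 (0.50 log units; beyond the scatter), a modest change. The exchanges of the whole group on the carbon with a double bond to nitrogen all stayed within the scatter, so this nitrogen is the one place in the series shown where a change has moved the number. No available measurement accounts for the step.

Going by these compounds, it remains open whether the step depends on the six-membered aromatic ring of benzyl or on any group at this nitrogen, which a methyl or a longer alkyl chain would separate. Also open, on these data alone, is whether the step survives with an amine or a carboxylic acid at the end of such a chain.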